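Benzamide substituent change in the shared core series

The source may hold more compounds than are shown below. What is called first, only, known or untested is meant among the compounds shown, and "the series" means these compounds.

Of the compounds shown here, three on one shared core have been measured in a functional assay on HCT-116 cells (Homo sapiens) for inhibition, read by luminescence and resazurin assay, with a stated time of 3 days; on this read-out higher numbers stand for weaker inhibition and lower numbers for stronger inhibition. Compound 1 `CCCNc1nc(NCc2ccc(NC(=O)c3ccc(F)cc3)cc2)c2ccccc2n1` gives 1700 nM. Compound 2 `CN1CCN(c2nc(NCc3ccc(NC(=O)c4ccc(F)cc4)cc3)c3ccccc3n2)CC1` gives 1800 nM, and a 1.1-fold higher number from compound 1 to compound 2 (0.02 log units; within the scatter). Compound 3 `CN(C)CCCNc1nc(NCc2ccc(NC(=O)c3ccc(F)cc3)cc2)c2ccccc2n1` gives 10000 nM, the highest number of the three: a 5.9-fold higher number from compound 1 to compound 3 (0.77 log units; beyond the scatter), and a 5.6-fold higher number from compound 2 to compound 3 (0.74 log units; beyond the scatter). Compound 3 therefore stands at the weak end of what has been measured, separated from both others by steps beyond the scatter.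

Compound 4 `CN(C)CCCNc1nc(NCc2ccc(NC(=O)c3ccc(CN4CCN(C)CC4)cc3)cc2)c2ccccc2n1` is not yet measured. It differs from compound 3 in one place: (4-methylpiperazin-1-yl)methyl in place of fluoro on an aromatic carbon. Among the compounds with values here, every measured step so far alters the substituent on the core at the other end of the molecule; none touches the benzamide ring where this change sits, so no measured step bears directly on it. The only related observation is that a 4-methylpiperazin-1-yl group elsewhere, in the step of a 1.1-fold higher number from compound 1 to compound 2 (0.02 log units; within the scatter), moved the number within the scatter, but that was a different position and a different attachment. Within the data shown here, with no direct precedent, the expectation is a step of no clear direction in this assay, with wide uncertainty, and the estimated step of a 1.3-fold lower number from compound 3 to compound 4 (0.10 log units; within the scatter) reflects that. Compound 4 is estimated at 8000 nM, within a range of 2500 nM to 30000 nM.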

Compound 4, half-maximal inhibitory concentration: > 20000 nM
Compound 4 gave a limit, no number (the forecaster's own chance of this, stated with the estimate: 25%); middle value at least 2.5-fold (0.39 log units) away from the limit.
By their numbers in this assay, from the lowest: compounds 1 and 2 (each within the scatter of the next); then compound 3. At a limit, above all of these: compound 4.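

Within the data shown here, this is the first change at this place, on an aromatic carbon of a six-membered aromatic ring of carbon only, para to a large group. In this assay, among these compounds, the entry of (4-methylpiperazin-1-yl)methyl for fluoro gives an at least 2.0-fold higher number from compound 3 to compound 4 (0.30 log units; that floor lies within the scatter) and brings no stronger inhibition, something the earlier steps could not show, as they all changed a different place. As far as these compounds go, the reading of compound 4 is a limit and not a number, so the step has only a floor and its true size stays unknown: the limit of > 20000 nM in this assay, at which 1 of the 4 values shown sits.

Open, from the compounds shown here alone, is whether a small group such as methyl or methoxy, or a morpholin-4-ylmethyl group, at this place would keep the level of compound 3 or also lose inhibition. Also open, going by these compounds, is whether (4-methylpiperazin-1-yl)methyl in place of fluoro would give the same outcome on the propylamino substituent of compound 1 or the 4-methylpiperazin-1-yl substituent of compound 2, since the change is seen here only with the (3-(dimethylamino)propyl)amino substituent.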